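The compounds below may be only part of what the source reports. "The series", "measured", "known", "first", "only" and "open" are said of these compounds alone.

Of the compounds shown here, three have been tested in a functional assay (thoracic aorta, strain Wistar) for inhibition, with Rattus norvegicus as the target; on this read-out lower numbers stand for stronger inhibition and higher numbers for weaker inhibition. Compound 1 `CO[C@@]12CCN(C)C[C@H]1[C@H](c1ccccc1)C(C#N)=C(N)O2` gives 720000 nM in this assay. Compound 2 `CCN1CC[C@@]2(OC)OC(N)=C(C#N)[C@@H](c3ccccc3)[C@@H]2C1` differs from compound 1 by methyl in place of hydrogen on a saturated chain carbon bound to an amine nitrogen in a ring; in this assay compound 2 gives 680000 nM, and the step is a 1.1-fold lower number from compound 1 to compound 2 (0.02 log units; within the scatter). Compound 3 `CO[C@@]12CCN(C)C[C@H]1[C@H](c1cccs1)C(C#N)=C(N)O2` keeps the amine substituent of compound 1 but carries a different aromatic group; in this assay compound 3 gives 680000 nM, a step of a 1.1-fold lower number from compound 1 to compound 3 (0.02 log units; within the scatter). Compound 2 and compound 3 stand level at the digits given, so no order can be read among these three numbers.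

Compound 4 `CCN1CC[C@@]2(OC)OC(N)=C(C#N)[C@@H](c3cccs3)[C@@H]2C1` has not yet been measured. It differs from compound 3 by methyl in place of hydrogen on a saturated chain carbon bound to an amine nitrogen in a ring, the same change already seen from compound 1 to compound 2, made on the same kind of place. The two cores on which this change is made differ from each other by thiophen-2-yl in place of phenyl on a saturated ring carbon. Since that core difference itself made only a step within the scatter, the change from compound 3 to compound 4 is expected to behave much as it did before. This rests on compound 1 and compound 2, where the same change gave a 1.1-fold lower number from compound 1 to compound 2 (0.02 log units; within the scatter). The expected step is a 1.0-fold lower number from compound 3 to compound 4 (0.02 log units; within the scatter). Compound 4 is therefore estimated to give about 650000 nM in this assay, most likely somewhere between 350000 nM and 1200000 nM.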

Compound 4, half-maximal inhibitory concentration: 490000 nM
Compound 4: middle estimate off by 1.3-fold (0.12 log units), on the high side, within the range that was stated.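

In this assay, methyl in place of hydrogen on a saturated chain carbon bound to an amine nitrogen in a ring gives a 1.4-fold lower number from compound 3 to compound 4 (0.14 log units; within the scatter), while thiophen-2-yl in place of phenyl on a saturated ring carbon gives a 1.4-fold lower number from compound 2 to compound 4 (0.14 log units; within the scatter). Each change has now been read on two cores, and the methyl change reads alike on both: the same change on two cores in this assay, a 1.1-fold lower number (0.02 log units; within the scatter) from compound 1 to compound 2 and a 1.4-fold lower number (0.14 log units; within the scatter) from compound 3 to compound 4, 1.3-fold (0.12 log units) apart, within the scatter of two such steps The thiophen-2-yl change also reads alike on both, but with only two cores and all four steps within the scatter, this shows only that neither change gives a clear step in these compounds, not that a change with a large effect would carry over or that these two would behave alike on other cores: the same change on two cores in this assay, a 1.1-fold lower number (0.02 log units; within the scatter) from compound 1 to compound 3 and a 1.4-fold lower number (0.14 log units; within the scatter) from compound 2 to compound 4, 1.3-fold (0.12 log units) apart, within the scatter of two such steps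

The compounds shown leave open whether a longer chain, such as propyl, at the same place on the chain would give a step beyond the scatter. They also leave open whether a different aromatic group, such as 4-chlorophenyl, on the saturated ring carbon would do so, and whether either change would then read alike on both cores.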